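This account rests on a few compounds, and the source may have more. Where it says the series, first, only, none or still open, it means among the compounds named here.

Compound 1 `CC(C)c1ccc(-c2nc(SCc3cn(CC(=O)NC(=O)Nc4ccccn4)nn3)nc(Nc3ccccc3Cl)c2C#N)cc1` gives 23400 nM in a functional assay on ECa-109 cells (Homo sapiens) for inhibition, read by MTT assay, with a stated time of 72 h; a higher number here means a weaker inhibitor, a lower number a stronger inhibitor. Going by the values given here, it stands alongside the only other measured compound, compound 2 `CC(C)c1ccc(-c2nc(SCc3cn(CC(=O)NC(=O)Nc4ccccn4)nn3)nc(Nc3cccc([N+](=O)[O-])c3)c2C#N)cc1`, which gives 31300 nM in this assay; the step of a 1.3-fold higher number from compound 1 to compound 2 (0.13 log units; within the scatter) is the sole measured comparison. Compound 3 `Cc1ccc(Nc2nc(SCc3cn(CC(=O)NC(=O)Nc4ccccn4)nn3)nc(-c3ccc(C(C)C)cc3)c2C#N)cc1` differs from compound 1 by 4-methylphenyl in place of 2-chlorophenyl on a nitrogen on an aromatic ring. Among the compounds with values here, the one step that bears on it, a swap of the aryl group on the same nitrogen, was a 1.3-fold higher number from compound 1 to compound 2 (0.13 log units; within the scatter), so no step beyond the scatter is expected here. The expected step is a 1.1-fold higher number from compound 1 to compound 3 (0.03 log units; within the scatter). Compound 3 is therefore estimated at 25000 nM, with a range of 10000 nM to 60000 nM.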

Compound 3, half-maximal inhibitory concentration: 6700 nM
Compound 3: the middle estimate sits 3.7-fold (0.57 log units) above what was measured; measured number outside the range, below it.
By their numbers in this assay, from the lowest: compound 3; then compounds 1 and 2 (each within the scatter of the next).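

The aryl group on the nitrogen does affect the number in this assay: 4-methylphenyl gives a 3.5-fold lower number from compound 1 to compound 3 (0.54 log units; beyond the scatter) and a 4.7-fold lower number from compound 2 to compound 3 (0.67 log units; beyond the scatter), whereas the swap between the 2-chlorophenyl and 3-nitrophenyl groups gave no step beyond the scatter. Changes at this position can therefore shift the number beyond the scatter, though only modestly here. No measurement at hand explains this step.

As far as these compounds go, it remains open whether the step follows the methyl group, its place on the ring or the loss of chlorine. An unsubstituted phenyl or an aminophenyl on the same nitrogen would bear on this.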